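Sulfamate Amides: Swapping the Para Amine Side Chain

This account rests on a few compounds, and the source may have more. Where it says the series, first, only, none or still open, it means among the compounds named here.

This account looks at three sulfamate compounds that share one core and then asks what a fourth, still untested, might show. Compound 2 `CC(C)CCN(CCC(C)C)c1ccc(C(=O)N2CCc3ccc(OS(N)(=O)=O)cc3C2)cc1` stands highest of the three in an assay on HEK293 cells for inhibition of Steryl-sulfatase (Homo sapiens), tested at 0.1 uM (a higher number here means a stronger effect of the compound at the concentration tested, a lower number a weaker effect), where compound 2 gives 47%. Compound 1 `NS(=O)(=O)Oc1ccc2c(c1)CN(C(=O)c1ccc(N3CCN(Cc4ccccc4)CC3)cc1)CC2` comes nearest, and in this assay compound 1 gives 20.8%, a number beyond the scatter below compound 2. Compound 3 `CCN(Cc1ccccc1)Cc1ccc(S(=O)(=O)N2CCc3ccc(OS(N)(=O)=O)cc3C2)cc1` lies furthest away, and in this assay compound 3 gives 10%, again beyond the scatter below compound 2.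

Compound 4 `CN(CCN1CCCCC1)c1ccc(C(=O)N2CCc3ccc(OS(N)(=O)=O)cc3C2)cc1` differs from compound 2 in a single place: methyl(2-(piperidin-1-yl)ethyl)amino in place of diisopentylamino on an aromatic carbon. Going by the values given here, no measured pair shows this particular exchange, so its size cannot be read from the table. The only other amide of the set sits well under compound 2 in this assay, where compound 1 gives 20.8%. On that ground a downward step is expected for compound 4, beyond the scatter, as a number 22 percentage points lower from compound 2 to compound 4 (beyond the scatter). In this assay compound 4 is estimated at 25%, with a range from 8% to 45%.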

Compound 4, a percentage reported as inhibition, at one concentration (the size of the read-out at that concentration, not a potency): 0.3%
Estimate against measurement, compound 4: 24.7 percentage points above; the whole stated range lies above it.
By their numbers in this assay, from the lowest: compounds 4 and 3 (each within the scatter of the next); then compound 1; then compound 2.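

Exchanging diisopentylamino for methyl(2-(piperidin-1-yl)ethyl)amino on this aromatic carbon gives, in this assay, a number 46.7 percentage points lower from compound 2 to compound 4 (beyond the scatter). Going by these compounds alone, this is the first direct reading at this position, as no earlier pair differed in this one place, and it shows that the large step can arise from this single exchange while the rest of the molecule stays the same. Nothing measured here accounts for the step.

The compounds shown leave open which part of the entering group goes with the loss: the piperidine ring, its added nitrogen, or the absence of the isopentyl chains. Also open, going by these compounds, is whether a diethylamino or a morpholin-4-yl group on the same aromatic carbon would stay close to compound 2 or fall close to compound 4.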